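A few compounds are considered here, and "the series" means these few. Any claim that something is new, unique, unknown or untested is made for them only; others in the source may bear on it.

Compound 1 `OCc1cnn(-c2nc(Nc3ccc(C(F)(F)F)cc3)c3ncn([C@@H]4O[C@H](CO)[C@@H](O)[C@H]4O)c3n2)c1` and compound 2 `CCOC(=O)c1cnn(-c2nc(NC3CCCCC3)c3ncn([C@@H]4O[C@H](CO)[C@@H](O)[C@H]4O)c3n2)c1` share a common core and differ in two places. In an assay on CHO cells for displacement of a labelled ligand from adenosine receptor A3 (Homo sapiens) (on this read-out higher numbers stand for weaker inhibition and lower numbers for stronger inhibition), compound 1 gives 15 nM, while compound 2 gives 30 nM. Compound 1 stands at the lower of the two numbers, but the gap to compound 2 lies within the usual scatter of this kind of measurement, so the two count as alike. Compound 3 `Cc1ccc(Nc2nc(-n3cc(CO)cn3)nc3c2ncn3[C@@H]2O[C@H](CO)[C@@H](O)[C@H]2O)cc1` keeps everything in compound 1 except one change, (methyl in place of trifluoromethyl on an aromatic carbon), that is, methyl in place of trifluoromethyl on an aromatic carbon. For the measured compounds named here, no measured pair shows this exact change, so the expectation rests on the two measured compounds alone. The step of a 2.0-fold higher number from compound 1 to compound 3 (0.30 log units; within the scatter) is expected to be small, a slight rise that need not go beyond the scatter. Compound 3 is therefore estimated at 30 nM, with a likely range from 8 nM to 110 nM.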

Compound 3, inhibition constant: 94 nM
Compound 3: the middle estimate sits 3.1-fold (0.50 log units) below what was measured; low and high end bracket the measured number.
By their numbers in this assay, from the lowest: compounds 1 and 2 (each within the scatter of the next); then compound 3.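

In this assay, exchanging trifluoromethyl for methyl gives a 6.3-fold higher number from compound 1 to compound 3 (0.80 log units; beyond the scatter), a modest but real loss of inhibition. For the compounds shown here, this pair is the first sign that the read-out responds to the group at this place, on an aromatic carbon para to a large group, even though neither group carries a hydrogen-bond donor, a hydrogen-bond acceptor or a net charge. No supporting data are available to explain why the two groups differ.

What the compounds shown leave open is how other groups at this place would compare, such as a chlorine atom, a methoxy group or an amine. A single pair also cannot tell whether the same exchange would produce a similar step if the rest of compound 1 were changed.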